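This account rests on a few compounds, and the source may have more. Where it says the series, first, only, none or still open, it means among the compounds named here.

Measured compounds and their numbers in an assay on HeLa cells for displacement of a labelled ligand from 5-hydroxytryptamine receptor 6 (Homo sapiens); a higher number here means a weaker inhibitor, a lower number a stronger inhibitor:

compound 1 `O=S(=O)(c1ccc(Cl)cc1)c1cn(C2CCCNC2)c2ncccc12` — 7.6 nM
compound 2 `CN1CCCC(n2cc(S(=O)(=O)c3ccc(Cl)cc3)c3cccnc32)C1` — 11.5 nM
compound 3 `CCN1CCCC(n2cc(S(=O)(=O)c3ccc(Cl)cc3)c3cccnc32)C1` — 33.5 nM

Compound 2 stands second highest of the three numbers in this assay. Its nearest neighbour is compound 1: the step of a 1.5-fold higher number from compound 1 to compound 2 (0.18 log units; within the scatter) lies within the scatter, so the two are not separated. Its furthest neighbour is compound 3: the step of a 2.9-fold higher number from compound 2 to compound 3 (0.46 log units; beyond the scatter) lies beyond the scatter, as does the step of a 4.4-fold higher number from compound 1 to compound 3 (0.64 log units; beyond the scatter).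

Compound 4 `CN1CCCC(n2cc(S(=O)(=O)c3cc(Cl)cc(Cl)c3)c3cccnc32)C1` is not yet measured. It differs from compound 2 in one place: 3,5-dichlorophenyl in place of 4-chlorophenyl on a sulfonyl sulfur. Every measured step in the series concerns the amine nitrogen in the ring and what is bound to it; none touches the group on the sulfonyl sulfur. Among the compounds with values here, no measured step therefore bears on this change, and there is no ground to expect movement in this assay in either direction beyond the scatter. The shared core and the amine substituent of compound 2 are kept unchanged.

For compound 4 the expected number in this assay is 15 nM, with a range from 4 nM to 60 nM. Within the data shown here, the expected step from compound 2 is a 1.3-fold higher number from compound 2 to compound 4 (0.12 log units; within the scatter), wide in its uncertainty because no measured step covers the group on the sulfonyl sulfur.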

Compound 4, inhibition constant: 3.9 nM
The estimate for compound 4 lay 3.8-fold (0.59 log units) above the measured number, and the stated range ends above it.
By their numbers in this assay, from the lowest: compounds 4, 1 and 2 (each within the scatter of the next, the first and the last beyond it); then compound 3.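

Working notes: in this assay, the group on the sulfonyl sulfur is a position where the number moves, which the earlier compounds could not show, as all their steps lay on the amine nitrogen in the ring and what is bound to it. Putting 3,5-dichlorophenyl in place of 4-chlorophenyl gives a 2.9-fold lower number from compound 2 to compound 4 (0.47 log units; beyond the scatter), so a second chlorine on the aryl group is tolerated here and goes with a lower number, not a higher one. The step runs in the opposite direction to the one on the amine side, a 2.9-fold higher number from compound 2 to compound 3 (0.46 log units; beyond the scatter), and no measurement in hand accounts for it.

The compounds shown do not separate the added chlorine from the changed placing of the chlorines, and a phenyl without chlorine, or a phenyl with fluorine or methyl groups in place of the chlorines, would bear on how much the halogen itself matters. As far as these compounds go, it also stays open whether 3,5-dichlorophenyl gives a step of this size with the hydrogen of compound 1 or the ethyl of compound 3 on the amine nitrogen.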